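From 4-fluorobenzyl to 2,4-difluorobenzyl: one added fluoro

A few compounds are considered here, and "the series" means these few. Any claim that something is new, unique, unknown or untested is made for them only; others in the source may bear on it.

Measured in a functional assay on Raji cells (Homo sapiens) for antiproliferative activity, read by MTT assay, with a stated time of 72 h (on this read-out lower numbers stand for stronger inhibition and higher numbers for weaker inhibition), the three compounds read as follows

- compound 1 `CN(Cc1nc(C2CCN(Cc3ccccc3)CC2)no1)c1ncc(/C=C/C(=O)NO)cn1` gives 547 nM
- compound 2 `Cc1ccc(CN2CCC(c3noc(CN(C)c4ncc(/C=C/C(=O)NO)cn4)n3)CC2)cc1` gives 293 nM
- compound 3 `CN(Cc1nc(C2CCN(Cc3ccc(F)cc3)CC2)no1)c1ncc(C(=O)NO)cn1` gives 22 nM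

Compound 3 stands lowest of the three at 22 nM and its gaps to the other two lie beyond the scatter. Compound 4 `CN(Cc1nc(C2CCN(Cc3ccc(F)cc3F)CC2)no1)c1ncc(C(=O)NO)cn1` has not yet been measured. It departs from compound 3 by fluoro in place of hydrogen on an aromatic carbon in one place, fluoro in place of hydrogen on an aromatic carbon, which turns 4-fluorobenzyl into 2,4-difluorobenzyl. Among the compounds with values here, only one measured step bears on this, and only loosely. That step is a 1.9-fold lower number from compound 1 to compound 2 (0.27 log units; within the scatter) and it concerns methyl in place of hydrogen on an aromatic carbon, a different group in compounds that also differ from compound 3 elsewhere. Within the data shown here, no measured step shows fluoro entering. No shift beyond the scatter is therefore expected in this assay and no direction can be named. The expected change is a 1.1-fold lower number from compound 3 to compound 4 (0.04 log units; within the scatter) and this remains an estimate. For compound 4 the estimated value is 20 nM with an expected range from 9 nM to 45 nM once it is measured.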

Compound 4, half-maximal inhibitory concentration: 34.3 nM
The estimate for compound 4 lay 1.7-fold (0.23 log units) below the measured number; the range from low to high includes it.
By their numbers in this assay, from the lowest: compounds 3 and 4 (each within the scatter of the next); then compounds 2 and 1 (each within the scatter of the next).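

In this assay, within the data shown here, the change from 4-fluorobenzyl to 2,4-difluorobenzyl gives a 1.6-fold higher number from compound 3 to compound 4 (0.19 log units; within the scatter), the first direct reading of fluoro entering on an aromatic carbon, ortho to a large group and meta to a fluoro group. The step lies within the scatter, so this carbon accepts a fluoro in place of hydrogen without a change that can be told apart in this read-out, and compound 3 and compound 4 cannot be ordered. No measurement shown explains this result.

The compounds shown leave open whether a group with more heavy atoms on this same carbon, such as methoxy, trifluoromethyl or an amine, would stay within the scatter of compound 3. They also leave open whether this fluoro would read the same without the fluoro of 4-fluorobenzyl.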